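Chain extension of a difluorinated alcohol: working notes

The source may report more compounds than this note shows. Statements on the series, on what has been measured and on what is new or still open speak of the compounds shown alone.

Compound 2 `OCCCC(F)F` gives 0.29 in a physicochemical assay for lipophilicity, read by NMR; a higher number here means a more lipophilic compound, a lower number a more polar compound. Compound 1 `OCCCCC(F)F` gives 0.66 in this assay; the step of a number 0.37 log units higher from compound 2 to compound 1 (beyond the scatter) corresponds to hydroxymethyl in place of hydroxy on a saturated chain carbon, four bonds along the chain from two fluorine atoms. Compound 3 `CCC(F)(F)CO` gives 0.67 in this assay; the difference between the core of compound 3 and the core of compound 2 is not broken down here. Compound 4 `CCC(F)(F)CCO` is not yet measured in this assay. It differs from compound 3 by hydroxymethyl in place of hydroxy on a saturated chain carbon, two bonds along the chain from two fluorine atoms, the same kind of change as that from compound 2 to compound 1, though here the carbon carrying it lies two bonds along the chain from two fluorine atoms rather than four. Among the measured compounds shown here, the step of a number 0.38 log units higher from compound 3 to compound 4 (beyond the scatter) is expected to be similar, because a number 0.37 log units higher from compound 2 to compound 1 (beyond the scatter) is the only measured step of this kind. Compound 4 is therefore estimated at 1.05, within 0.7 to 1.4.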

Compound 4, partition coefficient: 0.92
Compound 4: the middle estimate sits 0.13 log units above what was measured, within the range that was stated.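

On the core of compound 3, the change from hydroxy to hydroxymethyl gives a number 0.25 log units higher from compound 3 to compound 4 (within the scatter) in this assay, while the same change gives a number 0.37 log units higher from compound 2 to compound 1 (beyond the scatter) on the other core. The step beyond the scatter is therefore not confirmed on the second core, but this does not show that the change has no effect there, and two pairs cannot establish whether the steps truly differ or how well the change carries between cores. No measurement shown bears on the reason for this result.

The compounds shown leave open how this step behaves on a longer chain. They also leave open what an amine or a carboxylic acid would give in place of hydroxy.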